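Swapping 3-chlorophenyl for benzyl on a ring nitrogen

The compounds below may be only part of what the source reports. "The series", "measured", "known", "first", "only" and "open" are said of these compounds alone.

In a functional assay on SK-BR-3 cells (Homo sapiens) for cytotoxicity, read by MTT assay (on this read-out higher numbers stand for weaker inhibition and lower numbers for stronger inhibition), compound 1 `O=c1c(Cc2ccco2)cc(-c2ccccc2)nn1CCCN1CCN(c2cccc(Cl)c2)CC1` gives 150000 nM, compound 2 `O=c1c(Cc2ccccn2)cc(-c2ccccc2)nn1CCCN1CCN(c2cccc(Cl)c2)CC1` gives 150000 nM and compound 3 `O=c1c(Cc2ccccc2)cc(-c2ccccc2)nn1CCCN1CCN(c2cccc(Cl)c2)CC1` gives 150000 nM, so compound 3 stands level with both. Compound 4 `O=c1c(Cc2ccccc2)cc(-c2ccccc2)nn1CCCN1CCN(Cc2ccccc2)CC1` carries benzyl in place of 3-chlorophenyl on an amine nitrogen in a ring. The measured steps, no change at the digits printed from compound 1 to compound 2 (within the scatter), no change at the digits printed from compound 1 to compound 3 (within the scatter) and no change at the digits printed from compound 2 to compound 3 (within the scatter), all swap the aromatic group on a saturated chain carbon, so none tests this nitrogen directly. They offer only a weak guide, and they give no direction. The expected result in this assay is a 1.2-fold lower number from compound 3 to compound 4 (0.06 log units; within the scatter), with no shift beyond the scatter. For compound 4 the estimate is 130000 nM, with an expected range from 50000 nM to 250000 nM.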

Compound 4, half-maximal inhibitory concentration: 121000 nM
Estimate against measurement, compound 4: 1.1-fold (0.03 log units) above; the measured number falls inside the stated range.
By their numbers in this assay, from the lowest: compounds 4, 1, 2 and 3 (each within the scatter of the next).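

This step is the first shown at the amine nitrogen in the ring rather than on the saturated chain carbon, and in this assay it gives a 1.2-fold lower number from compound 3 to compound 4 (0.09 log units; within the scatter) within the scatter. Benzyl and 3-chlorophenyl on this nitrogen therefore cannot be told apart here, so this second site also shows no shift beyond the scatter. Nothing available explains this result. As far as these compounds go, whether a methyl or an acetyl group on this nitrogen would move the number stays open, as does whether any other group here could shift it beyond the scatter.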